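Carbamoyl in place of cyano on compound 3

The source may report more compounds than this note shows. Statements on the series, on what has been measured and on what is new or still open speak of the compounds shown alone.

Going by the values given here, in a physicochemical assay for solubility, read by nephelometry, in phosphate buffer, measured as kinetic solubility, with a stated time of 30 min, at pH 6.5 (on this read-out higher numbers stand for higher solubility and lower numbers for lower solubility), compound 3 `CS(=O)(=O)c1ccc(-c2cnc(N)c(-c3ccc(C#N)cc3)c2)cc1` gives 1.6 ug/mL, the lowest of the three numbers measured so far. Compound 1 `COc1ccc(-c2cc(-c3ccc(S(C)(=O)=O)cc3)cnc2N)cn1` gives 121 ug/mL, and compound 2 `CS(=O)(=O)c1ccc(-c2cnc(N)c(-c3ccc(CO)nc3)c2)cc1` gives 25 ug/mL.

The next entry is compound 4 `CS(=O)(=O)c1ccc(-c2cnc(N)c(-c3ccc(C(N)=O)cc3)c2)cc1`, which carries carbamoyl in place of cyano on an aromatic carbon, para to a large group: carbamoyl in place of cyano on an aromatic carbon.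

Among the compounds with values here, no measured step makes this exchange directly. The closest evidence is the pair of steps that bring in 4-cyanophenyl: a 16-fold lower number from compound 2 to compound 3 (1.19 log units; beyond the scatter) and a 76-fold lower number from compound 1 to compound 3 (1.88 log units; beyond the scatter). Both are large and both go downward, but each replaces a whole ring, so neither isolates the cyano group. Only part of their size can reasonably be carried over to the reverse direction. The third step, a 4.8-fold lower number from compound 1 to compound 2 (0.68 log units; beyond the scatter), is modest and also goes downward, so exchanging a single group on an aromatic carbon does not guarantee a rise.

In this assay, a modest rise is therefore expected, a 3.1-fold higher number from compound 3 to compound 4 (0.49 log units; beyond the scatter), although no change beyond the scatter remains possible. Compound 4 is estimated at 5 ug/mL, with an expected range of 1.5 ug/mL to 20 ug/mL.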

Compound 4, solubility: 25 ug/mL
Compound 4: the middle estimate sits 5.0-fold (0.70 log units) below what was measured; the whole stated range lies below it.
By their numbers in this assay, from the lowest: compound 3; then compounds 2 and 4 (each within the scatter of the next); then compound 1.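

In this assay the exchange of cyano for carbamoyl on an aromatic carbon, para to a large group, gives a 16-fold higher number from compound 3 to compound 4 (1.19 log units; beyond the scatter) as a large step. Going by these compounds alone, that step matches in size a 16-fold lower number from compound 2 to compound 3 (1.19 log units; beyond the scatter) even though it leaves the six-membered aromatic ring of carbon only in place, so the low number of compound 3 does not go with that ring alone: changing the single group on it moves the read-out as far as the whole-ring exchange did. Within the data shown here, the only earlier single-group step, a 4.8-fold lower number from compound 1 to compound 2 (0.68 log units; beyond the scatter) on a different ring, went the other way, so the series now holds single-group exchanges of both directions, and nothing measured on these compounds explains why this one is so large.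

Still open, going by these compounds, is whether a carboxylic acid, an aminomethyl group or an N-methyl carbamoyl at the same place would follow carbamoyl or stay nearer cyano, which would separate the entering hydrogen-bond donor from the rest of the exchange. Also open, on these data alone, is whether carbamoyl would give a similar number on the pyridine ring carried by compound 1 and compound 2.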